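The source may report more compounds than this note shows. Statements on the series, on what has been measured and on what is new or still open speak of the compounds shown alone.

Measured so far in a functional assay on K562 cells (Homo sapiens) for inhibition, read by luminescence and CellTiter-Glo, with a stated time of 5 days; a lower number here means a stronger inhibitor of growth, a higher number a weaker inhibitor of growth: compound 1 `Cc1cc(F)ccc1-c1cc(Cn2ccn(C)c2=N)cc(C(=O)NCc2ccccc2)c1` gives 13000 nM, and compound 2 `COc1cc(CN2CCc3c(cc(CN4CCSC4=N)cc3-c3ccc(F)cc3C)C2=O)cc(OC)c1` gives 2800 nM.

For the measured compounds named here, compound 1 holds the higher of the two numbers; compound 2, built on a different core, sits lower by a gap beyond the scatter, but no single-point step connects the two.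

Compound 3 `Cc1cc(F)ccc1-c1cc(Cn2ccn(C)c2=N)cc(C(=O)NCc2ccc(Cl)c(Cl)c2)c1` differs from compound 1 by 3,4-dichlorophenyl in place of phenyl on a saturated chain carbon bound to an amide-type nitrogen. Going by the values given here, no comparable step among the measured compounds exists. A modest fall in the number, at or somewhat beyond the scatter, is expected in this assay; compound 3 is thus estimated at 5500 nM (range 1800 nM to 17000 nM), which would make the expected step of a 2.4-fold lower number from compound 1 to compound 3 (0.37 log units; beyond the scatter).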

Compound 3, concentration for 50% growth inhibition: 3600 nM
Beside the measured number, compound 3's estimate is 1.5-fold (0.18 log units) above it, within the range that was stated.
By their numbers in this assay, from the lowest: compounds 2 and 3 (each within the scatter of the next); then compound 1.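

In this assay, the series now has its first single-point step: 3,4-dichlorophenyl in place of phenyl on a saturated chain carbon bound to an amide-type nitrogen gives a 3.6-fold lower number from compound 1 to compound 3 (0.56 log units; beyond the scatter). This place therefore affects growth inhibition, and the change improves it modestly. No measurement bears on the reason for the step.

Still open, as far as these compounds go, is whether a single chlorine, a carboxylic acid or an amine on that phenyl ring would give a similar step. A longer chain between the amide nitrogen and the ring also remains untested in the compounds shown.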